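Indole for methylsulfonylphenyl on the amide chain

This account rests on a few compounds, and the source may have more. Where it says the series, first, only, none or still open, it means among the compounds named here.

Compound 1 `CCC(C)[C@H](N)c1cc(C(F)(F)F)ccc1N1CCN(C(=O)CCc2ccc(Cl)cc2)CC1`: 86 nM
Compound 2 `CC(C)C[C@H](N)c1cc(C(F)(F)F)ccc1N1CCN(C(=O)CCc2ccc(S(C)(=O)=O)cc2)CC1`: 4900 nM

In an assay on HEK293 cells for displacement of a labelled ligand from Melanocortin receptor 4 (Homo sapiens) (on this read-out higher numbers stand for weaker inhibition and lower numbers for stronger inhibition), compound 2 gives 4900 nM, the highest of the two numbers; compound 1 gives 86 nM, a gap beyond the scatter. Compound 3 `Cc1[nH]c2ccccc2c1CCC(=O)N1CCN(c2ccc(C(F)(F)F)cc2[C@@H](N)CC(C)C)CC1` differs from compound 2 by 2-methyl-1H-indol-3-yl in place of 4-(methylsulfonyl)phenyl on a saturated chain carbon, two bonds along the chain from a carbonyl carbon. Going by the values given here, no measured pair isolates this change, so the expectation rests only on these two values. A lower number for compound 3 than for compound 2 is expected, with a 16-fold lower number from compound 2 to compound 3 (1.21 log units; beyond the scatter) as the estimated step. Compound 3 is thus expected to give about 300 nM, within the range 60 nM to 1500 nM.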

Compound 3, inhibition constant: 1600 nM
Compound 3: middle estimate off by 5.3-fold (0.73 log units), on the low side; measured number outside the range, above it.
By their numbers in this assay, from the lowest: compound 1; then compound 3; then compound 2.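

In this assay, going by these compounds alone, this pair gives the first reading of a single change on the amide chain: 2-methyl-1H-indol-3-yl in place of 4-(methylsulfonyl)phenyl gives a 3.1-fold lower number from compound 2 to compound 3 (0.49 log units; beyond the scatter), a modest step. The 4-(methylsulfonyl)phenyl group is therefore not needed at this position to keep binding measurable, and a group with no hydrogen-bond acceptors does better here. No available evidence accounts for the step. Still open, going by these compounds, is whether 1H-indol-3-yl without the methyl, or a longer chain carrying the indole, would lower the number further. Also open, on these data alone, is whether the step holds on the core of compound 1.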